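Sulfonyl ring swap: oxetanyl to cyclopropyl on compound 1

A few compounds are considered here, and "the series" means these few. Any claim that something is new, unique, unknown or untested is made for them only; others in the source may bear on it.

Compound 1 `O=C([C@@H]1CCCN(S(=O)(=O)c2ccc(S(=O)(=O)C3COC3)cc2)C1)N1CCC(F)(F)CC1` is the most potent of the three measured compounds in a functional assay on MIA PaCa-2 cells (Homo sapiens) for inhibition, read by MTT assay, with a stated time of 7 days (a higher number here means a weaker inhibitor, a lower number a stronger inhibitor), with a value of 110 nM. The nearest number belongs to compound 2 `CCN(CC)S(=O)(=O)c1ccc(S(=O)(=O)N2CCC[C@@H](C(=O)N3CCOCC3)C2)cc1`, which gives 350 nM, and the furthest to compound 3 `CCN(CC)S(=O)(=O)c1ccc(S(=O)(=O)N2CCC[C@@H](C(=O)NC3CCOCC3)C2)cc1`, which gives 3770 nM. Going by the values given here, the only single-point step measured so far, an 11-fold higher number from compound 2 to compound 3 (1.03 log units; beyond the scatter), sits on the carbonyl side of the shared core and leaves the sulfonyl side untouched.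

Compound 4 `O=C([C@@H]1CCCN(S(=O)(=O)c2ccc(S(=O)(=O)C3CC3)cc2)C1)N1CCC(F)(F)CC1` differs from compound 1 only on the other side of the core: cyclopropyl in place of oxetan-3-yl on a sulfonyl sulfur. Among the compounds with values here, no measured pair in this set varies the group on that sulfonyl sulfur, so the large step from compound 2 to compound 3 does not bear on this change, and the size of its effect is not anchored by any measured step. With nothing pointing to a large shift, the step from compound 1 to compound 4 is expected to stay close to the scatter, a 1.4-fold higher number from compound 1 to compound 4 (0.13 log units; within the scatter), with the direction uncertain.

Compound 4 is therefore estimated at 150 nM in this assay, within a range of 50 nM to 450 nM, because compound 1 gives 110 nM and the new group replaces a neighbour of similar size.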

Compound 4, half-maximal inhibitory concentration: 26 nM
For compound 4 the middle estimate is 5.8-fold (0.76 log units) above the measured one, outside the stated range (below it).
By their numbers in this assay, from the lowest: compound 4; then compound 1; then compound 2; then compound 3.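

In this assay the group on the sulfonyl sulfur is now shown to count: the change to cyclopropyl in place of oxetan-3-yl gives a 4.2-fold lower number from compound 1 to compound 4 (0.63 log units; beyond the scatter) and lies beyond the scatter. Going by these compounds alone, this is the first measured step on that side of the shared core, so the series responds there as well as on the carbonyl side, where the single earlier step was an 11-fold higher number from compound 2 to compound 3 (1.03 log units; beyond the scatter) and ran towards a higher number. The exchange takes out the ring oxygen, the one hydrogen-bond acceptor of the leaving group, and shrinks the four-membered ring to a three-membered one, yet nothing on hand explains the lower number.

On these data alone, whether the step follows the lost oxygen or the smaller ring stays open, as the two change together in this pair; cyclobutyl on the sulfonyl sulfur would keep the four-membered ring without the oxygen, and an open chain such as isopropyl would remove the ring altogether. Also open, as far as these compounds go, is whether cyclopropyl on the sulfonyl sulfur gives a similar step when morpholin-4-yl sits on the carbonyl carbon.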